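The compounds below may be only part of what the source reports. "The series", "measured", "known", "first", "only" and "open" are said of these compounds alone.

The two measured compounds:
Compound 1 `Clc1[nH]ccc2ncnc1-2` gives < 5% in a functional assay on EL4 cells (Mus musculus) for inhibition, tested at 100 uM (a lower number here means less inhibition, a higher number more inhibition at the concentration tested (going by the name of the read-out)), which is a limit of the assay rather than a number.
Compound 2 `OC[C@H]1OC(n2cnc3c(Cl)nccc32)[C@H](O)[C@@H]1O` gives < 5% in this assay, again a limit and not a number.

Compound 1 therefore stands at the floor of what this assay can report: the limit of < 5% in this assay, at which 2 of the 2 values shown sit. Nothing measured sets it apart from compound 2. The unmeasured compound 3 `CNc1[nH]ccc2ncnc1-2` differs from compound 1 in one place: methylamino in place of chloro on an aromatic carbon. Going by the values given here, no step between measured compounds is known, so the size of change to expect in this assay can rest only on the fact that both measured values are limits. A shift of modest size toward more inhibition is expected, and quite possibly none beyond the scatter. Compound 3 is estimated at 8%, with a range from 0% to 30%. The expected step is a number at least 3 percentage points higher from compound 1 to compound 3 (that floor lies within the scatter), with a fair chance that the assay reports only a limit again.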

Compound 3, a percentage reported as inhibition, at one concentration (the size of the read-out at that concentration, not a potency): < 5%
Compound 3: only a limit was reported (the forecaster's own chance of this, stated with the estimate: 55%); at least 3 percentage points between middle value and limit.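

Compound 1 and compound 3 each give only a limit, so no step from chloro to methylamino can be read in this assay: the limit of < 5% in this assay, at which 3 of the 3 values shown sit.

The compounds shown leave open whether any group on the shared core gives inhibition that this assay can report as a number.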